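Cytotoxicity limits and a dimethoxypyrimidinyl extension

This account rests on a few compounds, and the source may have more. Where it says the series, first, only, none or still open, it means among the compounds named here.

Three compounds have been measured in an ADME assay on BJ cells (Homo sapiens) for cytotoxicity, read by CellTiter-Glo and resazurin assay, with a stated time of 72 h; a lower number here means that less compound is needed, a higher number that more compound is needed for the effect:
compound 1, `CC(C)N(Cc1cccc(OCCCCCC(=O)O)c1)C(=O)c1ccccc1`, gives > 26000 nM
compound 2, `CC(C)N(Cc1cccc(OCCCCCC(=O)O)c1)C(=O)c1ccc(-c2cccc(S(C)(=O)=O)c2)cc1`, gives > 26000 nM
compound 3, `CCOC(=O)CCCCCOc1cccc(CN(C(=O)c2ccccc2)C(C)C)c1`, gives > 26000 nM

For compound 3 this value is a limit of the assay and not a number. The same holds for compound 1, and again for compound 2. Thus the limit of > 26000 nM in this assay, at which 3 of the 3 values shown sit, describes every value shown, and compound 3 stands nowhere else than at that limit. Among the measured compounds shown here, two measured steps touch this set: a step that the two limits leave unreadable from compound 1 to compound 2 and a step that the two limits leave unreadable from compound 1 to compound 3, and neither can be read, since both ends sit at the limit. Compound 4, `CCOC(=O)CCCCCOc1cccc(CN(C(=O)c2ccc(-c3cnc(OC)nc3OC)cc2)C(C)C)c1`, differs from compound 3 by 2,4-dimethoxypyrimidin-5-yl in place of hydrogen on an aromatic carbon. The step from compound 1 to compound 2, which adds a different aromatic group at a comparable kind of position, gave no readable change, so no readable step bears on the present change. The estimated step that the limit leaves unreadable from compound 3 to compound 4 is therefore expected to be none beyond the scatter. Compound 4 is expected to give about 40000 nM in this assay, most likely again as a limit, within 15000 nM to 150000 nM.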

Compound 4, half-maximal effective concentration: > 26000 nM
Compound 4 gave a limit, no number (the forecaster's own chance of this, stated with the estimate: 85%); the middle value lies beyond the limit too.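

No step can be read from compound 3 to compound 4 in this assay, because both values are limits of the assay and not numbers: the limit of > 26000 nM in this assay, at which 4 of the 4 values shown sit.

The compounds shown leave open what concentration of any of them gives the effect in this assay, and whether any of these changes shifts it.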